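Methoxy removal on the fluoro-bearing amide

The compounds below may be only part of what the source reports. "The series", "measured", "known", "first", "only" and "open" are said of these compounds alone.

Compound 3 `COc1ccc(-n2ccc(=O)c(C(=O)Nc3ccc(Oc4ccnc5[nH]ccc45)c(F)c3)n2)cc1` is measured in a functional assay on A549 cells (Homo sapiens) for cytotoxicity, read by MTT assay, with a stated time of 72 h (a lower number here means a stronger inhibitor, a higher number a weaker inhibitor), only as a limit, > 60000 nM. That places compound 3 at the limit of > 60000 nM in this assay, at which 1 of the 3 values shown sits, so no number is available for it, only the floor of the assay. Compound 1 `COc1ccc(-n2ccc(=O)c(C(=O)Nc3ccc(Oc4ccnc5[nH]ccc45)cc3)n2)cc1`, which lacks the fluoro, gives 53100 nM in this assay. Compound 2 `O=C(Nc1ccc(Oc2ccnc3[nH]ccc23)cc1)c1nn(-c2ccccc2)ccc1=O` gives 10500 nM. The two measured steps are a 5.1-fold lower number from compound 1 to compound 2 (0.70 log units; beyond the scatter) and an at least 1.1-fold higher number from compound 1 to compound 3 (0.05 log units; that floor lies within the scatter).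

Compound 4 `O=C(Nc1ccc(Oc2ccnc3[nH]ccc23)c(F)c1)c1nn(-c2ccccc2)ccc1=O` differs from compound 3 by hydrogen in place of methoxy on an aromatic carbon. For the measured compounds named here, the same methoxy-to-hydrogen change is the one seen in a 5.1-fold lower number from compound 1 to compound 2 (0.70 log units; beyond the scatter), a modest lowering beyond the scatter, and it is the only step that bears directly on this change. Because an at least 1.1-fold higher number from compound 1 to compound 3 (0.05 log units; that floor lies within the scatter) stays within the scatter, the fluoro is taken to add little on its own. Going by these compounds, the step of an at least 4.6-fold lower number from compound 3 to compound 4 (0.66 log units; beyond the scatter) is therefore expected to be a lowering of similar size, though from a limit the true start is unknown. Compound 4 is estimated at 13000 nM, expected to fall between 5000 nM and 40000 nM.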

Compound 4, half-maximal inhibitory concentration: 56800 nM
Beside the measured number, compound 4's estimate is 4.4-fold (0.64 log units) below it; the measured number lies above the stated range.
By their numbers in this assay, from the lowest: compound 2; then compounds 1 and 4 (each within the scatter of the next). At a limit, above all of these: compound 3.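

Starting from a limit, an at least 1.0-fold lower number from compound 3 to compound 4 (0.02 log units; that floor lies within the scatter) cannot be sized, so the lowering seen on removing the methoxy without the fluoro is not shown to carry over to the fluoro-bearing core: the same change on two cores in this assay, a 5.1-fold lower number (0.70 log units; beyond the scatter) from compound 1 to compound 2 and an at least 1.0-fold lower number (0.02 log units; that floor lies within the scatter) from compound 3 to compound 4; the limit leaves it open whether they differ
The fluoro could not be read on the methoxy-bearing core, but a 5.4-fold higher number from compound 2 to compound 4 (0.73 log units; beyond the scatter) gives it a modest step beyond the scatter where the 4-methoxyphenyl has become phenyl. The fluoro is therefore not neutral in every setting in this series, although whether its step differs between the two cores remains unsettled: the same change on two cores in this assay, an at least 1.1-fold higher number (0.05 log units; that floor lies within the scatter) from compound 1 to compound 3 and a 5.4-fold higher number (0.73 log units; beyond the scatter) from compound 2 to compound 4; the limit leaves it open whether they differ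

Going by these compounds, the size of the methoxy change on the fluoro-bearing core stays open while compound 3 has only a limit. Also open, on these data alone, is how an amine or a hydroxyl in place of the methoxy, on the same aromatic carbon, would read in this assay on either core.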